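Furan in place of chlorophenyl on a thiosemicarbazone

This account rests on a few compounds, and the source may have more. Where it says the series, first, only, none or still open, it means among the compounds named here.

Three thiosemicarbazones sharing one core were measured in a functional assay on UACC-62 cells (Homo sapiens) for inhibition, read by sulforhodamine B assay, with a stated time of 48 h; a higher number here means a weaker inhibitor of growth, a lower number a stronger inhibitor of growth. Compound 1 `COc1ccc(/C=N/NC(=S)NC(C)(C)[C@H]2CC=C(C)CC2)cc1` gives 70400 nM, compound 2 `CC1=CC[C@H](C(C)(C)NC(=S)N/N=C/c2ccccc2O)CC1` gives 10800 nM, and compound 3 `CC1=CC[C@H](C(C)(C)NC(=S)N/N=C/c2ccccc2Cl)CC1` gives 98000 nM. Compound 3 therefore shows the highest of the three numbers; its nearest neighbour is compound 1, with a 1.4-fold higher number from compound 1 to compound 3 (0.14 log units; within the scatter), while compound 2 lies furthest away, with a 9.1-fold higher number from compound 2 to compound 3 (0.96 log units; beyond the scatter). The only large movements seen so far involve the hydroxy group, as in a 6.5-fold lower number from compound 1 to compound 2 (0.81 log units; beyond the scatter).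

Compound 4 `CC1=CC[C@H](C(C)(C)NC(=S)N/N=C/c2ccco2)CC1` differs from compound 3 in one place: furan-2-yl in place of 2-chlorophenyl on a carbon with a double bond to nitrogen. Within the data shown here, no measured step replaces the whole aromatic ring, so nothing bears on it directly. The closest guide is the swap between two substituted phenyl rings without a hydroxy group, which stayed within the scatter. A step of no more than the scatter is therefore expected in this assay, and compound 4 is estimated at 75000 nM, within 25000 nM to 200000 nM, meaning an expected step of a 1.3-fold lower number from compound 3 to compound 4 (0.12 log units; within the scatter).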

Compound 4, concentration for total growth inhibition: 14100 nM
Estimate against measurement, compound 4: 5.3-fold (0.73 log units) above; the whole stated range lies above it.
By their numbers in this assay, from the lowest: compounds 2 and 4 (each within the scatter of the next); then compounds 1 and 3 (each within the scatter of the next).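

In this assay, replacing the whole aromatic ring at this place gave clear steps (a 7.0-fold lower number from compound 3 to compound 4 (0.84 log units; beyond the scatter)) and (a 5.0-fold lower number from compound 1 to compound 4 (0.70 log units; beyond the scatter)), whereas the swap between the two substituted phenyl rings without a hydroxy group had stayed within the scatter. A step of this size therefore does not depend on a hydroxy group, since furan-2-yl carries none and still leaves compound 4 level with the hydroxy compound (a 1.3-fold higher number from compound 2 to compound 4 (0.12 log units; within the scatter)). Nothing measured here gives a reason for this step.

Still open, from the compounds shown here alone, is whether the step goes with the ring oxygen, the five-membered ring or the loss of the substituent on the phenyl ring. A thiophene ring or a plain phenyl ring at this place would help separate these.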